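Cytotoxicity notes on a diaryl-amidoxime sulfone series

A few compounds are considered here, and "the series" means these few. Any claim that something is new, unique, unknown or untested is made for them only; others in the source may bear on it.

Measured compounds in an ADME assay on THP-1 cells (Homo sapiens) for cytotoxicity, read by flow cytometry, with a stated time of 72 h; on this read-out lower numbers stand for stronger inhibition and higher numbers for weaker inhibition:
compound 1 `N/C(=N\O)c1ccc(Nc2ccc(C3=C(S(=O)(=O)c4ccc(/C(N)=N/O)cc4)CC(c4ccccc4)(c4ccccc4)O3)cc2)cc1`, 48900 nM;
compound 2 `CC1(Cc2ccccc2)CC(S(=O)(=O)c2ccc(Nc3ccc(/C(N)=N/O)cc3)cc2)=C(c2ccc(/C(N)=N/O)cc2)O1`, 47600 nM;
compound 3 `N/C(=N\O)c1ccc(S(=O)(=O)C2=C(c3ccc(Nc4cccc(/C(N)=N/O)c4)cc3)OC(c3ccccc3)(c3ccccc3)C2)cc1`, 48100 nM.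

For the measured compounds named here, all three numbers sit close together, and no compound can be set apart from the others on this read-out. Compound 3 differs from compound 1 by a group of 10 heavy atoms (7 carbon, 2 nitrogen, 1 oxygen; one six-membered aromatic ring of carbon only) in place of a group of 10 heavy atoms (7 carbon, 2 nitrogen, 1 oxygen; one six-membered aromatic ring of carbon only), on a nitrogen on an aromatic ring; the step it made is a 1.0-fold lower number from compound 1 to compound 3 (0.01 log units; within the scatter). Compound 2 carries a different core from compound 1, and the difference between the two cores is not broken down here.

Compound 4 `CC1(Cc2ccccc2)CC(S(=O)(=O)c2ccc(Nc3cccc(/C(N)=N/O)c3)cc2)=C(c2ccc(/C(N)=N/O)cc2)O1` has not yet been measured in this assay. It differs from compound 2 by a group of 10 heavy atoms (7 carbon, 2 nitrogen, 1 oxygen; one six-membered aromatic ring of carbon only) in place of a group of 10 heavy atoms (7 carbon, 2 nitrogen, 1 oxygen; one six-membered aromatic ring of carbon only), on a nitrogen on an aromatic ring, the same change as that from compound 1 to compound 3. Since that earlier step, a 1.0-fold lower number from compound 1 to compound 3 (0.01 log units; within the scatter), stayed within the scatter, and compound 2 gives 47600 nM, a step of a 1.0-fold lower number from compound 2 to compound 4 (0.00 log units; within the scatter) is expected for compound 4. Compound 4 is therefore estimated at 47500 nM, with a likely range from 30000 nM to 75000 nM in this assay.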

Compound 4, half-maximal inhibitory concentration: 46600 nM
Estimate against measurement, compound 4: 1.0-fold (0.01 log units) above; low and high end bracket the measured number.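

In this assay, the exchange of one group for another with the same atoms, on a nitrogen on an aromatic ring, gives a 1.0-fold lower number from compound 2 to compound 4 (0.01 log units; within the scatter), and the two steps on the two cores agree: the same change on two cores in this assay, a 1.0-fold lower number (0.01 log units; within the scatter) from compound 1 to compound 3 and a 1.0-fold lower number (0.01 log units; within the scatter) from compound 2 to compound 4, 1.0-fold (0.00 log units) apart, within the scatter of two such steps

On this read-out, the exchange therefore carries from the core of compound 1 to the core of compound 2 without a step that can be told from the scatter on either core. This does not establish that steps transfer between cores in this series, since neither step leaves the scatter and so no real effect is available to follow from one core to the other; the finding also covers only these two pairs and this one cytotoxicity read-out.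

Still open, as far as these compounds go, is whether a carboxylic acid, a nitrile or a primary amide in place of the group on that nitrogen would give a number apart from these. Also open, from the compounds shown here alone, is whether a longer chain on the core would do so.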